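Swapping a ring for a ((4-bromophenyl)sulfonyl)amino group

This account rests on a few compounds, and the source may have more. Where it says the series, first, only, none or still open, it means among the compounds named here.

Of the compounds shown here, two that share a core have been tested so far in a functional assay on MGC-803 cells (Homo sapiens) for antiproliferative activity, read by MTT assay, with a stated time of 48 h; a higher number here means a weaker inhibitor, a lower number a stronger inhibitor. Compound 1 `COc1ccc(CN(C(=O)Cn2cc(COc3ccc4c(C)cc(=O)oc4c3)nn2)c2cc(OC)c(OC)c(OC)c2)cc1` gives 130 nM. Compound 2 `COc1ccc(CN(C(=O)Cn2cc(CSC3=NCCS3)nn2)c2cc(OC)c(OC)c(OC)c2)cc1` gives 1610 nM, the higher of the two numbers and therefore the weaker inhibitor, with a gap beyond the usual scatter. Compound 3 `COc1ccc(CN(C(=O)Cn2cc(CNS(=O)(=O)c3ccc(Br)cc3)nn2)c2cc(OC)c(OC)c(OC)c2)cc1` keeps the core of compound 2 and changes one group, on a saturated chain carbon bound to an aromatic carbon: a group of 11 heavy atoms (6 carbon, 1 nitrogen, 2 oxygen, 1 sulfur, 1 bromine; one six-membered aromatic ring of carbon only) in place of a group of 6 heavy atoms (3 carbon, 1 nitrogen, 2 sulfur; one five-membered non-aromatic ring with 2 hetero atoms), on a saturated chain carbon bound to an aromatic carbon. Among the compounds with values here, no measured pair isolates this change, so any forecast is loose. Within the data shown here, the only guide is compound 1 at 130 nM, which carries a larger group than compound 2 at that place and has the lower number. A moderate gain is expected in this assay, with an estimated 3.2-fold lower number from compound 2 to compound 3 (0.51 log units; beyond the scatter). Compound 3 is estimated at 500 nM, within an expected range of 120 nM to 2500 nM.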

Compound 3, half-maximal inhibitory concentration: 430 nM
For compound 3 the middle estimate is 1.2-fold (0.07 log units) above the measured one; measured number inside the range.
By their numbers in this assay, from the lowest: compound 1; then compound 3; then compound 2.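

Placing ((4-bromophenyl)sulfonyl)amino on the saturated chain carbon bound to an aromatic carbon gives, in this assay, a 3.7-fold lower number from compound 2 to compound 3 (0.57 log units; beyond the scatter). This shows that a sulfonyl-linked aromatic ring can stand at this place and still give a lower number than the five-membered non-aromatic ring with 2 hetero atoms, so the earlier gain seen with compound 1 is not a single case. Compound 3 gives 430 nM, while compound 1 gives 130 nM, and nothing measured here explains any of these differences.

It remains open which part of the new group matters, as the compounds shown do not separate the bromine from the rest of the group. Going by these compounds, how a plain phenylsulfonylamino group, a simple amine or a carboxylic acid would behave at this place also remains unknown.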